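Moving the chlorine on a chlorophenyl group

The source may report more compounds than this note shows. Statements on the series, on what has been measured and on what is new or still open speak of the compounds shown alone.

Compound 1 `Cc1ccsc1-c1cc(-c2ccc(Cl)o2)cc(-c2ccc(Cl)cc2)n1` gives 30300 nM
Compound 2 `Clc1cccc(-c2cc(-c3ccc(Cl)o3)cc(-c3ccc(Cl)s3)n2)c1` gives > 50000 nM

In a functional assay on HCT-15 cells (Homo sapiens) for cytotoxicity, read by ELISA, with a stated time of 4 days (a higher number here means a weaker inhibitor, a lower number a stronger inhibitor), compound 1 gives a real number of 30300 nM and so shows weak inhibition. Compound 2 stands at > 50000 nM and this is a limit of the assay, not a number.

Compound 3 `Clc1ccc(-c2cc(-c3ccc(Cl)o3)cc(-c3ccc(Cl)s3)n2)cc1` has not been measured yet. It has the same atoms as compound 2, joined differently in one place: 4-chlorophenyl in place of 3-chlorophenyl on an aromatic carbon. Here 4-chlorophenyl takes the place of 3-chlorophenyl on an aromatic carbon next to the ring nitrogen.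

Within the data shown here, no measured pair shows what this swap does, so any forecast is rough. Among the measured compounds shown here, compound 1 at 30300 nM is the only real number available, and it lies at the weak end of the scale. The expectation in this assay is therefore a small step toward stronger inhibition, or no step beyond the scatter, and another reading at the limit would be no surprise. The estimated change is an at least 1.5-fold lower number from compound 2 to compound 3 (0.19 log units; that floor lies within the scatter) in this forecast. Compound 3 is expected at about 32000 nM with an estimated range from 13000 nM to 50000 nM.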

Compound 3, half-maximal inhibitory concentration: 25300 nM
Compound 3: middle estimate off by 1.3-fold (0.10 log units), on the high side; low and high end bracket the measured number.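

In this assay, moving the chlorine from 3-chlorophenyl to 4-chlorophenyl, on an aromatic carbon next to the ring nitrogen, gives an at least 1.9-fold lower number from compound 2 to compound 3 (0.29 log units; that floor lies within the scatter). Among these compounds, this is the first look at this change, and it shows that the 4-chlorophenyl compound gives a real number in a series where the 3-chlorophenyl compound gives only a limit, so only a floor can be stated for the step: the limit of > 50000 nM in this assay, at which 1 of the 3 values shown sits. The other new comparison, 5-chlorothiophen-2-yl in place of 3-methylthiophen-2-yl, gives a 1.2-fold lower number from compound 1 to compound 3 (0.08 log units; within the scatter), so with a 4-chlorophenyl group in place, this swap on the other side of the core leaves the two compounds indistinguishable in this assay.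

Going by these compounds, how large the chlorine shift really is stays open, as the true value behind the limit could lie close to the floor or far beyond it. Also open, on these data alone, is what a 2-chlorophenyl group, or a phenyl ring carrying an amine or a carboxylic acid instead of chlorine, would give at this place, and whether any such group would bring the number far from the weak end of the scale.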